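Swapping the Carbamate Cap for Ethyl on the Azetidine

The source may report more compounds than this note shows. Statements on the series, on what has been measured and on what is new or still open speak of the compounds shown alone.

Measured so far in a functional assay on MIA PaCa-2 cells (Homo sapiens) for inhibition, read by MTT assay, with a stated time of 7 days; a lower number here means a stronger inhibitor, a higher number a weaker inhibitor:
compound 1 `CCN(CC)S(=O)(=O)c1ccc(S(=O)(=O)N2CCC[C@@H](C(=O)NC3CN(C(=O)OC(C)(C)C)C3)C2)cc1` — 200 nM
compound 2 `CCOC(=O)[C@@H]1C[C@H](O)CN(S(=O)(=O)c2ccc(S(=O)(=O)N(CC)CC)cc2)C1` — 1300 nM
compound 3 `CCOC(=O)[C@@H]1CCCN(S(=O)(=O)c2ccc(S(=O)(=O)N(C)Cc3ccccc3)cc2)C1` — > 30000 nM

All three share one core and differ at its edges. Compound 1 has the lowest of the two real numbers. Its nearest neighbour, compound 2, gives 1300 nM, a gap that is beyond the usual scatter. For compound 3 this assay reports only a limit, > 30000 nM, not a number.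

Compound 4 `CCN1CC(NC(=O)[C@@H]2CCCN(S(=O)(=O)c3ccc(S(=O)(=O)N(CC)CC)cc3)C2)C1` has not yet been measured. It differs from compound 1 in one place: ethyl in place of tert-butoxycarbonyl on an amine nitrogen in a ring. Among the measured compounds shown here, no measured pair shows this same change, so there is no direct guide to its size. The expected step of a 2.0-fold higher number from compound 1 to compound 4 (0.30 log units; within the scatter) is small, toward a slightly higher number, at the edge of the scatter. Compound 4 is therefore estimated at 400 nM, with a likely range from 100 nM to 1600 nM.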

Compound 4, half-maximal inhibitory concentration: > 30000 nM
Compound 4 ended at the assay's limit; the forecaster's own chance of this, stated with the estimate: 10%; at least 75-fold (1.87 log units) between middle value and limit.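

Among the compounds shown here, replacing tert-butoxycarbonyl with ethyl on the amine nitrogen of the four-membered ring gives an at least 150-fold higher number from compound 1 to compound 4 (2.17 log units; beyond the scatter) in this assay, so the group at this position has a large bearing on the read-out, which no earlier pair could test. The result for compound 4 is a limit and not a number, so this step is a lower bound on the true difference: the limit of > 30000 nM in this assay, at which 2 of the 4 values shown sit. The change removes the carbonyl and both oxygens of tert-butoxycarbonyl, along with its tert-butyl end, and ethyl brings no hydrogen-bond acceptors.

This single pair cannot show which of those parts matters. As far as these compounds go, it remains open whether an acetyl group, a methyl carbamate or a free amine on the same nitrogen would restore a value close to that of compound 1.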